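One stereocentre switched: compound 2 to compound 3

The source may report more compounds than this note shows. Statements on the series, on what has been measured and on what is new or still open speak of the compounds shown alone.

compound 1 `NCCCCN(C[C@@H]1CN(C(=O)c2ccco2)CCN1)[C@H]1CCCc2cccnc21` gives > 10 uM
compound 2 `NCCCCN(C[C@H]1CN(C(=O)OCc2ccccc2)CCN1)[C@H]1CCCc2cccnc21` gives > 10 uM

In an ADME assay on MAGI cells (Homo sapiens) for cytotoxicity (a higher number here means that more compound is tolerated, a lower number that less compound is tolerated), compound 2 gives > 10 uM as a limit of the assay, not a number. The evidence so far is the limit of > 10 uM in this assay, at which 2 of the 2 values shown sit, and so gives compound 2 no exact place. Compound 3 `NCCCCN(C[C@@H]1CN(C(=O)OCc2ccccc2)CCN1)[C@H]1CCCc2cccnc21` is separated from compound 2 by a single difference, the two compounds have the same atoms and bonds and differ only in configuration as drawn: 1 of 2 stereo elements differ; a stereocentre at a saturated ring carbon is drawn S in compound 2 and R in compound 3 and nothing else: the atoms and bonds stay the same. Among the compounds with values here, no measured step shows what such a switch does, so no change beyond the usual scatter is expected in this assay in either direction. The estimate amounts to an expected step that the limit leaves unreadable from compound 2 to compound 3 within that scatter. For compound 3 the estimated value is 15 uM with an expected range from 10 uM to 40 uM in this assay.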

Compound 3, half-maximal toxic concentration: > 10 uM
Compound 3: only a limit was reported; the forecaster's own chance of this, stated with the estimate: 85%; the middle value is on the limit's open side.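

Within the data shown here, the results for compound 1, compound 2 and compound 3 in this assay are all limits, so no step to compound 3 can be read. The compounds shown leave open whether switching the stereocentre or replacing furan-2-yl with benzyloxy changes tolerance at all.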